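Ethynyl in place of 1-benzofuran-2-yl, starting from a limit

This account rests on a few compounds, and the source may have more. Where it says the series, first, only, none or still open, it means among the compounds named here.

In a functional assay on HeLa S3 cells (Homo sapiens) for antiproliferative activity, read by XTT assay, with a stated time of 72 h (a lower number here means a stronger inhibitor, a higher number a weaker inhibitor), compound 1 `CNc1ncnc2c1c(-c1ccsc1)cn2[C@@H]1O[C@H](CO)[C@@H](O)[C@H]1O` gives > 20000 nM as a limit only. Compound 2 `CNc1ncnc2c1c(-c1cc3ccccc3o1)cn2[C@@H]1O[C@H](CO)[C@@H](O)[C@H]1O` gives > 20000 nM as a limit too, and nothing firmer places it. Compound 3 `C#Cc1cn([C@@H]2O[C@H](CO)[C@@H](O)[C@H]2O)c2ncnc(NC)c12` carries ethynyl in place of 1-benzofuran-2-yl on an aromatic carbon and is still unmeasured. Going by the values given here, the one measured step that the two limits leave unreadable from compound 1 to compound 2 has no readable size. The evidence amounts to the limit of > 20000 nM in this assay, at which 2 of the 2 values shown sit, and no more. Among the compounds with values here, with no sized step as a guide, a shift to a lower number in this assay is expected only tentatively, and a result at the limit remains likely. The expected step of an at least 1.3-fold lower number from compound 2 to compound 3 (0.12 log units; that floor lies within the scatter) is a wide estimate. For compound 3 the estimated value is 15000 nM within an expected range of 2000 nM to 40000 nM for now.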

Compound 3, half-maximal inhibitory concentration: > 20000 nM
Compound 3 was reported as a limit; the forecaster's own chance of this, stated with the estimate: 60%; middle value at least 1.3-fold (0.12 log units) from the limit.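

In this assay compound 3 gives > 20000 nM, a limit. Going by these compounds alone, no step among compound 1, compound 2 and compound 3 can be read. The compounds shown leave open whether any group on this aromatic carbon gives a measurable value in this assay.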